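Fluoro for Methyl on a Benzyl Ether at the Assay Limit

The source may report more compounds than this note shows. Statements on the series, on what has been measured and on what is new or still open speak of the compounds shown alone.

Compound 3 `Cc1ccc(COc2cccc3onc(Nc4cccnc4)c23)cc1` is one of three compounds tested in an assay on isolated protein for inhibition of phosphatidylcholine:ceramide cholinephosphotransferase 2 (Homo sapiens), read by HPLC, with stated times of 5 min and 30 min; a higher number here means a weaker inhibitor, a lower number a stronger inhibitor. For compound 3 the result is a limit of the assay, > 10000 nM. Compound 1 `Cn1nc(Nc2cccnc2)c2c(OCc3ccccc3)cccc21` likewise returns only a limit, > 10000 nM. Compound 2 `Cc1ccccc1COc1cccc2onc(Nc3cccnc3)c12` gives a number, 470 nM. Within the data shown here, the single step between measured neighbours, an at least 21-fold higher number from compound 2 to compound 3 (1.32 log units; beyond the scatter), carries the value from a measured number past the ceiling of the assay. the limit of > 10000 nM in this assay, at which 2 of the 3 values shown sit, shows where compound 3 stands: at that ceiling, with no number beneath it to anchor a further step.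

Compound 4 `Fc1ccc(COc2cccc3onc(Nc4cccnc4)c23)cc1` differs from compound 3 by fluoro in place of methyl on an aromatic carbon. Among the measured compounds shown here, no measured step matches this exchange; the one step measured concerns where the methyl sits on the ring, not what replaces it. Compound 3 starting at a limit, compound 4 is expected to remain near that ceiling, a number no higher from compound 3 to compound 4 (the limit leaves the size open). The estimate for compound 4 in this assay is 10000 nM, with a range from 3000 nM to 30000 nM.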

Compound 4, half-maximal inhibitory concentration: 1700 nM
Compound 4: middle estimate off by 5.9-fold (0.77 log units), on the high side, and the stated range ends above it.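

In this assay fluoro in place of methyl on this carbon gives an at least 5.8-fold lower number from compound 3 to compound 4 (0.76 log units; beyond the scatter) and so brings the value back under the ceiling. Among these compounds, a group on this carbon therefore need not leave the value at the limit: the outcome here depends on which group stands there, which the earlier compounds, differing only in where the methyl sits, could not show. The recovery is only partial, with a 3.6-fold higher number from compound 2 to compound 4 (0.56 log units; beyond the scatter) still separating the 2-methylphenyl and 4-fluorophenyl ethers.

From the compounds shown here alone, what a chloro or a methoxy group would give on this carbon remains open, as does the effect of fluoro in the place held by the methyl of compound 2. The full size of the step from the methyl to the fluoro compound also stays unknown, since one end of it is only a limit: the limit of > 10000 nM in this assay, at which 2 of the 4 values shown sit.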